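What replacing the amino link may do

The compounds below may be only part of what the source reports. "The series", "measured", "known", "first", "only" and "open" are said of these compounds alone.

- compound 1 `CC(C)C(=O)N1CCC(CNc2ccc(S(=O)(=O)NC(=O)c3ccc(N4CCN(CC5=C(c6ccc(C(F)(F)F)cc6)CC(C)(C)CC5)CC4)cc3Oc3cnc4[nH]ccc4c3)cc2[N+](=O)[O-])CC1` gives 5.3 nM 
- compound 2 `CC1(C)CCC(CN2CCN(c3ccc(C(=O)NS(=O)(=O)c4ccc(NCC5CCOC5)c([N+](=O)[O-])c4)c(Oc4cnc5[nH]ccc5c4)c3)CC2)=C(c2ccc(C(F)(F)F)cc2)C1` gives 24.2 nM 

In a functional assay on RS4-11 cells (Homo sapiens) for inhibition, read by CCK-8 assay, with a stated time of 72 h (on this read-out lower numbers stand for stronger inhibition and higher numbers for weaker inhibition), compound 2 (24.2 nM) holds the higher of the two numbers, so it is the weaker inhibitor. Compound 3 `CC1(C)CCC(CN2CCN(c3ccc(C(=O)NS(=O)(=O)c4ccc(OCC5CCOC5)c([N+](=O)[O-])c4)c(Oc4cnc5[nH]ccc5c4)c3)CC2)=C(c2ccc(C(F)(F)F)cc2)C1` carries (oxolan-3-yl)methoxy in place of ((oxolan-3-yl)methyl)amino on an aromatic carbon and nothing else changes. For the measured compounds named here, the one measured step is a 4.6-fold higher number from compound 1 to compound 2 (0.66 log units; beyond the scatter) and it altered the ring on the chain, not the linking atom, so it offers only a rough size. No measurement tests this swap directly. The expected change in this assay is modest and upward, a 1.9-fold higher number from compound 2 to compound 3 (0.27 log units; within the scatter) and this is only an estimate. For compound 3 the estimated value is 45 nM (range 12 nM to 170 nM).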

Compound 3, half-maximal inhibitory concentration: 47 nM
The estimate for compound 3 lay 1.0-fold (0.02 log units) below the measured number; measured number inside the range.
By their numbers in this assay, from the lowest: compound 1; then compounds 2 and 3 (each within the scatter of the next).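

At this position, the linking atom can change from nitrogen to oxygen, with (oxolan-3-yl)methoxy, which has 0 hydrogen-bond donors, in place of ((oxolan-3-yl)methyl)amino, which has 1. In this assay this gives a 1.9-fold higher number from compound 2 to compound 3 (0.29 log units; within the scatter), so the two compounds cannot be told apart, and the donor on the linking nitrogen shows no effect beyond the scatter in this pair. No available evidence explains this result.

From the compounds shown here alone, it remains open whether a sulfur atom or a methylene carbon as the link would also stay within the scatter. Also open, going by these compounds, is how the oxygen link would behave with the 1-(isopropylcarbonyl)piperidin-4-yl group of compound 1.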